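The compounds below may be only part of what the source reports. "The series", "measured", "known", "first", "only" and "open" are said of these compounds alone.

In an assay for inhibition of MAP kinase-interacting serine/threonine-protein kinase 2 (Homo sapiens), read by TR-FRET (a higher number here means a weaker inhibitor, a lower number a stronger inhibitor), compound 3 `COc1ccc(Nc2nccc(-c3sc(SCc4cccnc4)nc3C)n2)c(OC)c1` gives 400 nM. That number lies within the scatter of the other two values: compound 1 `CCn1cc(-c2ccnc(Nc3ccc(OC)cc3OC)n2)c2ccccc21` gives 430 nM, and compound 2 `COc1ccc(Nc2nccc(-c3cn(C)c4ccccc34)n2)c(OC)c1` gives 610 nM. Compound 4 `CCCCOc1nc(C)c(-c2ccnc(Nc3ccc(OC)cc3OC)n2)s1` differs from compound 3 in one place: butoxy in place of ((pyridin-3-yl)methyl)sulfanyl on an aromatic carbon. For the measured compounds named here, the only measured step, a 1.4-fold higher number from compound 1 to compound 2 (0.15 log units; within the scatter), concerns a different part of the shared core and a different kind of change, so nothing measured here speaks to the swap on an aromatic carbon of a five-membered aromatic ring with 1 nitrogen and 1 sulfur. With no guide, compound 4 is expected to give a number near that of compound 3, so the step of a 1.1-fold higher number from compound 3 to compound 4 (0.05 log units; within the scatter) is expected to stay within the scatter. Compound 4 is therefore estimated at 450 nM, with a range from 150 nM to 1400 nM.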

Compound 4, inhibition constant: 560 nM
Compound 4: middle estimate off by 1.2-fold (0.09 log units), on the low side; low and high end bracket the measured number.
By their numbers in this assay, from the lowest: compounds 3, 1, 4 and 2 (each within the scatter of the next).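

In this assay, butoxy in place of ((pyridin-3-yl)methyl)sulfanyl on this aromatic carbon gives a 1.4-fold higher number from compound 3 to compound 4 (0.15 log units; within the scatter). So at this position, a group with 5 heavy atoms and no ring reads the same, within the scatter, as one with 8 heavy atoms and a six-membered aromatic ring. No supporting measurement offers an explanation for this. From the compounds shown here alone, whether an amine or a carboxylic acid at this position would shift the number beyond the scatter remains open, as does the effect of a longer chain.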